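Hydroxy for ethyl on the side chain: transfer check

The source may report more compounds than this note shows. Statements on the series, on what has been measured and on what is new or still open speak of the compounds shown alone.

Measured so far in a functional assay on the whole organism (Tail, strain ICR) with Mus musculus as the target, in the tail flick test, with a stated time of 150 min, at a dose of 25 umol/kg by the oral route; on this read-out lower numbers stand for a weaker effect and higher numbers for a stronger effect at the one dose given:
- compound 1, `CC[C@H](C)[C@H](NC(=O)CN(c1nc(Cl)nc2[nH]cnc12)C1CC1)C(=O)O`, gives 6.71%
- compound 2, `CC[C@H](C)[C@H](NC(=O)CN(c1ncnc2c1ncn2C1CCCCO1)C1CC1)C(=O)OCc1ccccc1`, gives 16.4%
- compound 3, `C[C@@H](O)[C@H](NC(=O)CN(c1nc(Cl)nc2[nH]cnc12)C1CC1)C(=O)O`, gives 24%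

Compound 1 and compound 3 share a core and differ in one place: hydroxy in place of ethyl on a saturated chain carbon bound to two saturated chain carbons. This change gave a number 17.3 percentage points higher from compound 1 to compound 3 (beyond the scatter). Compound 2 carries a different core and a benzyl ester; its difference from compound 1 is not broken down here. Compound 2 and compound 3 stand within the scatter of each other, as do compound 2 and compound 1, so no order among them is read from these numbers.

Compound 4, `C[C@@H](O)[C@H](NC(=O)CN(c1ncnc2c1ncn2C1CCCCO1)C1CC1)C(=O)OCc1ccccc1`, is not yet measured. It differs from compound 2 by hydroxy in place of ethyl on a saturated chain carbon bound to two saturated chain carbons, the same change as from compound 1 to compound 3, at the same place. Among the compounds with values here, on the new core the expected step is a number 14.6 percentage points higher from compound 2 to compound 4 (beyond the scatter), resting on the single earlier instance a number 17.3 percentage points higher from compound 1 to compound 3 (beyond the scatter); with one precedent the range is kept wide. For compound 4 in this assay the estimate is 31%, between 12% and 50%.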

Compound 4, a percentage reported as activity, at one dose (the size of the read-out at that dose, not a potency): 6.53%
For compound 4 the middle estimate is 24.5 percentage points above the measured one; the whole stated range lies above it.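

In this assay, hydroxy in place of ethyl on a saturated chain carbon bound to two saturated chain carbons gives a number 9.9 percentage points lower from compound 2 to compound 4 (within the scatter) and so the rise seen with the carboxylic acids on the core of compound 1 does not carry over to the benzyl esters on the core of compound 2. The two instances of the change do not agree, and the change therefore cannot be carried from one core to the other in this series as a fixed increment: the same change on two cores in this assay, a number 17.3 percentage points higher (beyond the scatter) from compound 1 to compound 3 and a number 9.9 percentage points lower (within the scatter) from compound 2 to compound 4, 27.2 percentage points apart, beyond the scatter of two such steps. This does not show which feature sets the outcome, as the two pairs differ in both the core and the ester, and each setting rests on one pair at one dose and one time.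

The compounds shown leave open whether the core or the benzyl ester goes with the different outcome. They also leave open how an amine, a methoxy or a longer chain at the same place would read on either core.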